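Carbamate chain variation in an arylselenium series

The compounds below may be only part of what the source reports. "The series", "measured", "known", "first", "only" and "open" are said of these compounds alone.

Measured so far:
compound 1 `CCCCOC(=O)Nc1ccc([Se]C#N)cc1`, 5300 nM
compound 2 `CCOC(=O)Nc1ccc([Se][Se]c2ccc(NC(=O)OCC)cc2)cc1`, 5700 nM
compound 3 `CC(C)COC(=O)Nc1ccc([Se]C#N)cc1`, 5800 nM

The three values in an ADME assay on 184B5 cells (Homo sapiens) for cytotoxicity, read by MTT assay, with a stated time of 72 h (a lower number here means a stronger inhibitor of growth, a higher number a weaker inhibitor of growth), sit close together. Compound 3 carries the nominally highest number, but its gaps to compound 2 and to compound 1 both fall within the scatter, so no ordering among the three can be read from these data. For the measured compounds named here, the one step that can be traced through a single change, a 1.1-fold higher number from compound 1 to compound 3 (0.04 log units; within the scatter), is itself within the scatter.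

Compound 4 is `CCCCCCOC(=O)Nc1ccc([Se]C#N)cc1`. It differs from compound 3 as follows: pentyl in place of isopropyl on a saturated chain carbon bound to an oxygen next to a carbonyl group. This is again a change on the saturated chain carbon bound to an oxygen next to a carbonyl group, the same place altered between compound 1 and compound 3, where the number barely moved. Compound 2, with its different selenium arrangement, gives no further guidance on this position. On that basis no movement beyond the scatter is expected in this assay. The expected step is a 1.1-fold lower number from compound 3 to compound 4 (0.02 log units; within the scatter). Compound 4 is accordingly estimated at 5500 nM, with a range from 2500 nM to 12000 nM.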

Compound 4, concentration for 50% growth inhibition: 4600 nM
Beside the measured number, compound 4's estimate is 1.2-fold (0.08 log units) above it, within the range that was stated.
By their numbers in this assay, from the lowest: compounds 4, 1, 2 and 3 (each within the scatter of the next).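

Pentyl in place of isopropyl on a saturated chain carbon bound to an oxygen next to a carbonyl group gives a 1.3-fold lower number from compound 3 to compound 4 (0.10 log units; within the scatter) in this assay, and ethyl in place of hydrogen on a saturated chain carbon, four bonds along the chain from that oxygen, gives a 1.2-fold lower number from compound 1 to compound 4 (0.06 log units; within the scatter) in the same read-out. Both steps stay within the scatter, so a longer unbranched chain at this position separates compound 4 from neither compound 1 nor compound 3, and the flat picture now extends beyond a single change at this place. No measured evidence bears on this result.

Open, on these data alone, is whether a chain longer than hexyl would move the number beyond the scatter. Also open, as far as these compounds go, is what a terminal amine, a carboxylic acid or a phenyl ring on this chain would do in this assay on the shared core.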